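The source may report more compounds than this note shows. Statements on the series, on what has been measured and on what is new or still open speak of the compounds shown alone.

Measured so far in an ADME assay on Vero cells (Chlorocebus sabaeus) for cytotoxicity, read by MTT assay, with a stated time of 72 h; a lower number here means that less compound is tolerated, a higher number that more compound is tolerated:
- compound 1 `CO/N=C1/C(=O)N(CCCn2cc(CN3CCC[C@@H]4CN(c5c(F)cc6c(=O)c(C(=O)O)cn(C7CC7)c6c5OC)C[C@@H]43)nn2)c2ccc(C)cc21` gives 8 ug/mL
- compound 2 `COc1c(N2C[C@H]3CCCN(Cc4cn(CCCN5C(=O)C(=O)c6cc(F)ccc65)nn4)[C@H]3C2)c(F)cc2c(=O)c(C(=O)O)cn(C3CC3)c12` gives 16 ug/mL

The two values lie within the scatter of each other, so compound 2 stands level with compound 1 on the numbers available. Compound 3 `COc1c(N2C[C@H]3CCCN(Cc4cn(CCCN5C(=O)C(=O)c6ccccc65)nn4)[C@H]3C2)c(F)cc2c(=O)c(C(=O)O)cn(C3CC3)c12` departs from compound 2 by hydrogen in place of fluoro on an aromatic carbon, with hydrogen in place of fluoro on an aromatic carbon. Within the data shown here, no measured pair isolates this change. No shift beyond the scatter is expected in this assay, and the estimated 1.1-fold lower number from compound 2 to compound 3 (0.06 log units; within the scatter) is small. The expected value for compound 3 is 14 ug/mL with an estimated range of 6 ug/mL to 32 ug/mL overall.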

Compound 3, half-maximal cytotoxic concentration: 16 ug/mL
Compound 3: middle estimate off by 1.1-fold (0.06 log units), on the low side, and the stated range covers the measured number.
By their numbers in this assay, from the lowest: compounds 1, 2 and 3 (each within the scatter of the next).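

In this assay, among these compounds, the only single change that can be read is at this aromatic carbon, where hydrogen in place of fluoro gives no change at the digits printed from compound 2 to compound 3 (within the scatter) and leaves the tolerated concentration within the scatter. On this comparison, the fluoro is not required at this position to keep cytotoxicity at the level of compound 2. No measurement shown accounts for this outcome. As far as these compounds go, whether a larger substituent such as chloro or a nitrile on the same carbon would also leave the number in place remains open. From the compounds shown here alone, the effect of an amine at this position also remains open.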